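A few compounds are considered here, and "the series" means these few. Any claim that something is new, unique, unknown or untested is made for them only; others in the source may bear on it.

Measured so far, in a functional assay on DU-145 cells (Homo sapiens) for cytotoxicity, read by CCK-8 assay; a lower number here means a stronger inhibitor, a higher number a weaker inhibitor:
- compound 1 `Oc1cccc(-c2cc(-c3cccs3)cc(-c3ccccc3O)n2)c1`: 9300 nM
- compound 2 `Oc1ccc(-c2cc(-c3cccs3)cc(-c3ccccc3O)n2)cc1`: this value is a limit of the assay, > 50000 nM
- compound 3 `Oc1ccc(-c2cc(-c3ccoc3)cc(-c3cccc(O)c3)n2)cc1`: 2700 nM

Compound 4 `Oc1ccc(-c2cc(-c3ccoc3)cc(-c3ccc(O)cc3)n2)cc1` is not yet measured. How the core of compound 3 differs from that of compound 1 is not broken down here. Compound 2 sits at the limit of > 50000 nM in this assay, at which 1 of the 3 values shown sits. The change 4-hydroxyphenyl in place of 3-hydroxyphenyl on an aromatic carbon gave an at least 5.3-fold higher number from compound 1 to compound 2 (0.73 log units; beyond the scatter). The change 4-hydroxyphenyl in place of 3-hydroxyphenyl on an aromatic carbon is the same kind of change, though the surroundings differ: in compound 1 the place is meta to a 2-hydroxyphenyl group and meta to a thiophen-2-yl group, in compound 3 meta to a 4-hydroxyphenyl group and meta to a furan-3-yl group. Since compound 3 gives 2700 nM and the earlier step was at least modest, a weakening of similar size is expected, a 4.4-fold higher number from compound 3 to compound 4 (0.65 log units; beyond the scatter). Compound 4 is therefore estimated at 12000 nM, between 4000 nM and 50000 nM.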

Compound 4, half-maximal inhibitory concentration: 3440 nM
For compound 4 the middle estimate is 3.5-fold (0.54 log units) above the measured one; measured number below the stated range.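

In this assay, putting 4-hydroxyphenyl in place of 3-hydroxyphenyl gave a 1.3-fold higher number from compound 3 to compound 4 (0.11 log units; within the scatter), so on this core the swap makes no clear difference. The same swap does not carry over with the same size from one core to the other: the same change on two cores in this assay, an at least 5.3-fold higher number (0.73 log units; beyond the scatter) from compound 1 to compound 2 and a 1.3-fold higher number (0.11 log units; within the scatter) from compound 3 to compound 4, at least 4.2-fold (0.62 log units) apart, beyond the scatter of two such steps The two cores also differ in their other groups, thiophen-2-yl against furan-3-yl and 2-hydroxyphenyl against 4-hydroxyphenyl, and these two steps do not show which of those differences matters, or why.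

Compound 2 gives > 50000 nM, which is a limit of the assay. Also open, from the compounds shown here alone, is whether the swap would behave the same way with an amine or a carboxylic acid in place of the hydroxyl group on the phenyl ring.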